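Ring Size at the Cyclic Substituent: Cyclobutyl to Cyclohexyl

The source may hold more compounds than are shown below. What is called first, only, known or untested is meant among the compounds shown, and "the series" means these compounds.

Measured so far:
Compound 1, `Nc1cc(C2CCCC2)nc2ccc(NC(=O)/C=C/c3ccc(C(F)(F)F)cc3)cc12`: 68 nM
Compound 2, `Nc1cc(C2CCC2)nc2ccc(NC(=O)/C=C/c3ccc(C(F)(F)F)cc3)cc12`: 250 nM

In a functional assay on HEK293 cells for activation of melanin-concentrating hormone receptor 1 (Homo sapiens), read by inositol phosphate accumulation (a lower number here means that less compound is needed, a higher number that more compound is needed for the effect), compound 1 gives 68 nM. In this assay compound 2 gives 250 nM, the higher of the two numbers, so compound 2 stands at the top of what has been measured. Within the data shown here, the only measured step is a 3.7-fold higher number from compound 1 to compound 2 (0.57 log units; beyond the scatter), a change that replaced the five-membered ring with a four-membered one and raised the number beyond the scatter.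

Compound 3, `Nc1cc(C2CCCCC2)nc2ccc(NC(=O)/C=C/c3ccc(C(F)(F)F)cc3)cc12`, has not yet been measured. It differs from compound 2 by cyclohexyl in place of cyclobutyl on an aromatic carbon. Among the measured compounds shown here, the single step that bears on this change runs the opposite way, from the larger ring to the smaller, and was modest in size. Taken on its own, it suggests that going back to a larger ring should lower the number again, possibly to about where compound 1 sits.

Compound 3 is therefore expected to give roughly 70 nM. The expected range for compound 3 runs from 20 nM to 250 nM. The expected step, a 3.6-fold lower number from compound 2 to compound 3 (0.55 log units; beyond the scatter), is an estimate rather than a measurement.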

Compound 3, half-maximal effective concentration: 96 nM
The estimate for compound 3 lay 1.4-fold (0.14 log units) below the measured number; the range from low to high includes it.
By their numbers in this assay, from the lowest: compounds 1 and 3 (each within the scatter of the next); then compound 2.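

In this assay, enlarging the ring on this aromatic carbon from cyclobutyl to cyclohexyl gives a 2.6-fold lower number from compound 2 to compound 3 (0.42 log units; beyond the scatter) and shows that the higher number of compound 2 is not shared by the largest ring. Replacing cyclopentyl with cyclohexyl gives a 1.4-fold higher number from compound 1 to compound 3 (0.15 log units; within the scatter) and so leaves these two rings indistinguishable here, with cyclobutyl the only one of the three that stands apart. No available evidence explains this pattern.

These three compounds cannot show whether the number would stay level with a still larger ring, such as cycloheptyl. Also open, from the compounds shown here alone, is how an open-chain group such as isopropyl, or a ring containing an amine such as piperidinyl, would compare with these carbon rings in this assay at this position.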